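The compounds below may be only part of what the source reports. "The series", "measured", "known", "first", "only" and "open" are said of these compounds alone.

Measured so far:
- compound 1 `COc1ccc(C(=O)N(CCC(=O)NCc2ccccc2)Cc2ccc(C(=O)NO)cc2)cc1` — in a functional assay on SK-N-AS cells (Homo sapiens) for antiproliferative activity, with a stated time of 72 h (on this read-out lower numbers stand for stronger inhibition and higher numbers for weaker inhibition), compound 1 gives 1740 nM
- compound 2 `Cc1ccc(NC(=O)CCN(Cc2ccc(C(=O)NO)cc2)C(=O)c2ccc(N(C)C)cc2)cc1` — in this assay compound 2 gives 400 nM

Compound 1 stands at the higher of the two numbers; compound 2 sits at a lower number, and the gap between the two lies beyond the scatter, so compound 2 is the more potent of the pair. Compound 2 differs from compound 1 in more than one place, so nothing can be said about which part of that difference carries the gap.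

Compound 3 `Cc1cc(C)cc(C(=O)N(CCC(=O)NCc2ccccc2)Cc2ccc(C(=O)NO)cc2)c1` is the next one to be measured. It keeps the whole core of compound 1 and changes only the aryl group on the carbonyl carbon: 3,5-dimethylphenyl in place of 4-methoxyphenyl on a carbonyl carbon. For the measured compounds named here, no measured pair in the set isolates this kind of change, so there is no step to lean on. The expectation is that the step in this assay from compound 1 to compound 3 stays within the usual scatter, with no clear direction; the estimated step is a 1.2-fold lower number from compound 1 to compound 3 (0.06 log units; within the scatter). For compound 3 the value in this assay is estimated at 1500 nM, with a range from 600 nM to 4000 nM.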

Compound 3, half-maximal inhibitory concentration: 1860 nM
For compound 3 the middle estimate is 1.2-fold (0.09 log units) below the measured one; measured number inside the range.
By their numbers in this assay, from the lowest: compound 2; then compounds 1 and 3 (each within the scatter of the next).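

In this assay, for the compounds shown here, 3,5-dimethylphenyl in place of 4-methoxyphenyl on a carbonyl carbon gives a 1.1-fold higher number from compound 1 to compound 3 (0.03 log units; within the scatter), the first step that isolates a single place, and it lies within the scatter. This change removes the oxygen and the one hydrogen-bond acceptor of the leaving group and alters the substitution on the aryl ring, while the heavy-atom count stays the same, and no separate potency shift can be seen in this read-out. With the core of compound 1 held fixed, this position therefore tolerates this particular exchange, though that statement rests on one pair only, and no measurement beyond the potency numbers bears on the result.

As far as these compounds go, whether a pyridine ring, a carboxylic acid or a piperidine on this aryl position would move the number remains open. Compound 2 gives 400 nM, but it differs from compound 1 and compound 3 in more than one place, so the share of its aryl group, with its dimethylamino substituent, and of its other amide end in that gap remains unassigned.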